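The source may report more compounds than this note shows. Statements on the series, on what has been measured and on what is new or still open speak of the compounds shown alone.

Compound 1 `C=CCn1c(=O)/c(=C\c2cccc(Cl)c2)[nH]c(=O)/c1=C\c1ccccc1OC` gives 5200 nM in a functional assay on MCF7 cells (Homo sapiens) for cytotoxicity, read by CCK-8 assay, with a stated time of 72 h; a lower number here means a stronger inhibitor, a higher number a weaker inhibitor.
Compound 2 `C=CCn1c(=O)/c(=C\c2ccccc2Cl)[nH]c(=O)/c1=C\c1ccccc1OC` gives 4700 nM in this assay.
Compound 3 `C=CCn1c(=O)/c(=C\c2cccc(Cl)c2Cl)[nH]c(=O)/c1=C\c1ccccc1OC` gives 2100 nM in this assay.

Compound 1 has the highest number of the three. Its nearest neighbour is compound 2, reached by a 1.1-fold lower number from compound 1 to compound 2 (0.04 log units; within the scatter), so the two cannot be told apart. Its furthest is compound 3, reached by a 2.5-fold lower number from compound 1 to compound 3 (0.39 log units; beyond the scatter), a modest change; the matching a 2.2-fold lower number from compound 2 to compound 3 (0.35 log units; beyond the scatter) is of the same modest size.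

Compound 4 `C=CCn1c(=O)/c(=C\c2ccccc2F)[nH]c(=O)/c1=C\c1ccccc1OC` is not yet measured. It differs from compound 1 in one place: 2-fluorophenyl in place of 3-chlorophenyl on a double-bonded chain carbon bound to an aromatic carbon. Within the data shown here, only one measured step bears on this change, the move of the chloro from the 3-position to the 2-position of the phenyl ring in a 1.1-fold lower number from compound 1 to compound 2 (0.04 log units; within the scatter), which stayed within the scatter. Among the measured compounds shown here, no measured pair shows what fluoro in place of chloro does on this ring, so that part of the change is unsupported by the data. On this basis a step of no size beyond the scatter is expected in this assay, with the uncertainty widened by the untested halogen swap. Compound 4 is therefore estimated at 5500 nM, within 2500 nM to 12000 nM, which would mean a 1.1-fold higher number from compound 1 to compound 4 (0.02 log units; within the scatter).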

Compound 4, half-maximal inhibitory concentration: 23000 nM
Compound 4: middle estimate off by 4.2-fold (0.62 log units), on the low side, outside the stated range (above it).
By their numbers in this assay, from the lowest: compound 3; then compounds 2 and 1 (each within the scatter of the next); then compound 4.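

In this assay, among these compounds, the identity of the halogen on this phenyl ring matters more than the earlier compounds could show: fluoro in place of chloro on an aromatic carbon gives a 4.9-fold higher number from compound 2 to compound 4 (0.69 log units; beyond the scatter), whereas moving the chloro from the 3-position to the 2-position gave only a 1.1-fold lower number from compound 1 to compound 2 (0.04 log units; within the scatter). Among the compounds shown here, the change from 3-chlorophenyl to 2-fluorophenyl gives a step of the same modest size, a 4.4-fold higher number from compound 1 to compound 4 (0.65 log units; beyond the scatter), and the change from 2,3-dichlorophenyl to 2-fluorophenyl gives the only large step in the set, an 11-fold higher number from compound 3 to compound 4 (1.04 log units; beyond the scatter), so all three chloro-bearing compounds have lower numbers than the single fluoro compound, and none of the four goes against this. Nothing among the data offers an explanation for why fluoro and chloro differ here.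

The compounds shown leave open whether the rise in the number follows fluoro at any place on this ring or only in 2-fluorophenyl, and whether a second fluoro would lower the number as the second chloro did. They also leave open where a bromo, a methyl or a plain unsubstituted phenyl would fall relative to the chloro and fluoro compounds.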